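Changing the pendant aryl group of compound 1

This account rests on a few compounds, and the source may have more. Where it says the series, first, only, none or still open, it means among the compounds named here.

Compound 1 `Cc1ccccc1-c1cc(Cl)cc(Cl)c1/C=C/[C@@H]1C[C@@H](O)CC(=O)O1` gives 370 nM in an assay for inhibition of 3-hydroxy-3-methylglutaryl-coenzyme A reductase (Rattus norvegicus) (on this read-out higher numbers stand for weaker inhibition and lower numbers for stronger inhibition), the highest of the two numbers recorded there. Compound 2 `Cc1cc(C)c(CCC2C[C@@H](O)CC(=O)O2)c(-c2ccc(F)c(C)c2)c1`, which shares no single-point relationship with it, gives 22 nM in this assay, a clearly lower number that lies beyond the scatter. Compound 3 `COc1cccc(-c2cc(Cl)cc(Cl)c2/C=C/[C@@H]2C[C@@H](O)CC(=O)O2)c1` differs from compound 1 in one place: 3-methoxyphenyl in place of 2-methylphenyl on an aromatic carbon. Among the measured compounds shown here, no measured pair tracks such a change, so compound 3 is expected to stay close to compound 1, with a step of a 1.2-fold lower number from compound 1 to compound 3 (0.09 log units; within the scatter) not clearly beyond the scatter in either direction. Compound 3 is estimated at 300 nM, within 100 nM to 1000 nM.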

Compound 3, half-maximal inhibitory concentration: 50 nM
Compound 3: middle estimate off by 6.0-fold (0.78 log units), on the high side; measured number below the stated range.
By their numbers in this assay, from the lowest: compound 2; then compound 3; then compound 1.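

The pendant aryl group at this place on the core is not a neutral spot: in this assay, 3-methoxyphenyl in place of 2-methylphenyl gives a 7.4-fold lower number from compound 1 to compound 3 (0.87 log units; beyond the scatter), so the outcome depends on which aryl group sits there. The entering group also brings one hydrogen-bond acceptor that the leaving group lacks, yet nothing available accounts for the step. This one pair cannot separate the effect of the added oxygen from that of the substituent's different place on the ring. Going by these compounds, whether an amine or a carboxylic acid in place of the methoxy group would hold this gain remains open.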